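A few compounds are considered here, and "the series" means these few. Any claim that something is new, unique, unknown or untested is made for them only; others in the source may bear on it.

Among the three compounds measured so far, compound 3 `CCN(CC)c1nc(C)nc2c(-c3c(C)cc(N(C)C)nc3C)c(C)nn12` stands at the top of the numbers: in an assay on cell membranes for displacement of a labelled ligand from corticotropin-releasing factor receptor 1 (Rattus norvegicus) (a lower number here means a stronger inhibitor, a higher number a weaker inhibitor), compound 3 gives 58 nM. Compound 1 `CCC(CC)Nc1nc(C)nc2c(-c3cnc(N(C)C)cc3C)c(C)nn12` sits nearest to it, and in this assay compound 1 gives 24.8 nM, a difference that lies beyond the scatter. Compound 2 `CCN(CC)c1nc(C)nc2c(-c3cnc(OC)cc3C)c(C)nn12` is furthest away; in this assay compound 2 gives 14.5 nM, again beyond the scatter. No pair among these three differs in only one place, so no single-change step can be read off them.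

Compound 4 `CCN(CC)c1nc(C)nc2c(-c3cnc(N(C)C)cc3C)c(C)nn12` is the next compound to be tested. It is obtained from compound 3 by the change (hydrogen in place of methyl on an aromatic carbon), that is, hydrogen in place of methyl on an aromatic carbon. Since the two measured compounds with lower numbers, compound 1 and compound 2, share with compound 4 more of their structure than compound 3 does, a moderate downward step is expected, from compound 3 to compound 4 of about a 3.2-fold lower number from compound 3 to compound 4 (0.51 log units; beyond the scatter). The value estimated for compound 4 in this assay is 18 nM, within a range from 8 nM to 45 nM.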

Compound 4, half-maximal inhibitory concentration: 13.8 nM
Beside the measured number, compound 4's estimate is 1.3-fold (0.12 log units) above it; the measured number falls inside the stated range.
By their numbers in this assay, from the lowest: compounds 4, 2 and 1 (each within the scatter of the next); then compound 3.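

In this assay, going by these compounds alone, hydrogen in place of methyl on an aromatic carbon, at the place next to the ring nitrogen and ortho to a large group, gives a 4.2-fold lower number from compound 3 to compound 4 (0.62 log units; beyond the scatter) and is the first single change here to lie beyond the scatter. The other two changes do not separate their compounds: dimethylamino in place of methoxy gives a 1.1-fold lower number from compound 2 to compound 4 (0.02 log units; within the scatter) and diethylamino in place of (pentan-3-yl)amino gives a 1.8-fold lower number from compound 1 to compound 4 (0.25 log units; within the scatter) on the same shared core. No measurement at hand gives a reason for the step at the methyl position.

The compounds shown leave open how an ethyl group or a chlorine atom would read at this same place. From the compounds shown here alone, this step also rests on one pair, so it remains open whether a methyl there would give a similar step alongside the methoxy of compound 2 or the (pentan-3-yl)amino of compound 1.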